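A few compounds are considered here, and "the series" means these few. Any claim that something is new, unique, unknown or untested is made for them only; others in the source may bear on it.

Three compounds have been measured so far in a functional assay on A549 cells (Homo sapiens) for antiproliferative activity, read by MTT assay, with a stated time of 48 h; on this read-out lower numbers stand for stronger inhibition and higher numbers for weaker inhibition:

compound 1 `Cc1ccc2[nH]c(-c3cn(-c4ccccc4)nc3-c3ccccc3)nc2c1` gives 3610 nM
compound 2 `COc1ccc2[nH]c(-c3cn(-c4ccccc4)nc3-c3ccccc3)nc2c1` gives 1230 nM
compound 3 `FC(F)(F)c1ccc2[nH]c(-c3cn(-c4ccccc4)nc3-c3ccccc3)nc2c1` gives 5930 nM

Compound 2 has the lowest number of the three, and its gaps to both of the others lie beyond the scatter. Compound 4 `COc1ccc2[nH]c(-c3cn(-c4ccccc4)nc3-c3ccc(F)cc3)nc2c1` differs from compound 2 in one place, where phenyl becomes 4-fluorophenyl (fluoro in place of hydrogen on an aromatic carbon). Among the measured compounds shown here, no measured step touches this ring. All three steps exchange a group elsewhere on the shared core, so they offer only a rough sense of how far one small change can move the number. There is a 2.9-fold lower number from compound 1 to compound 2 (0.47 log units; beyond the scatter) and a 4.8-fold higher number from compound 2 to compound 3 (0.68 log units; beyond the scatter), both modest, while a 1.6-fold higher number from compound 1 to compound 3 (0.22 log units; within the scatter) stays within the scatter. None of them shows what a fluoro does here, so no direction can be expected with confidence, and a step within the scatter is the likeliest outcome in this assay. The estimated change is a 1.2-fold lower number from compound 2 to compound 4 (0.09 log units; within the scatter) and is expected to be small. For compound 4 the expected value is 1000 nM, with an estimated range from 400 nM to 2700 nM.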

Compound 4, half-maximal inhibitory concentration: 1960 nM
The estimate for compound 4 lay 2.0-fold (0.29 log units) below the measured number; low and high end bracket the measured number.
By their numbers in this assay, from the lowest: compounds 2, 4, 1 and 3 (each within the scatter of the next, the first and the last beyond it).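

In this assay, among the compounds shown here, the change from phenyl to 4-fluorophenyl gives a 1.6-fold higher number from compound 2 to compound 4 (0.20 log units; within the scatter) and is the first measured change on this ring, as the earlier steps all exchanged a group elsewhere on the shared core. At this place, on an aromatic carbon para to a large group, a fluoro cannot be told apart from hydrogen in this read-out. Nothing measured here offers a reason for this result.

Going by these compounds, this single small atom says little about how larger groups would behave on the same ring, so it remains open whether an amine or a carboxylic acid at this place would move the number beyond the scatter. On these data alone, it is also open whether a fluoro would give a similarly small step on the other phenyl ring, or with a group other than methoxy on the shared core.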